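A few compounds are considered here, and "the series" means these few. Any claim that something is new, unique, unknown or untested is made for them only; others in the source may bear on it.

Compound 1 `Cn1ncc(Cl)c1-c1cc(C(=O)N[C@@H]2CN[C@H](CCn3cncn3)C[C@H]2c2ccc(Cl)c(Cl)c2)oc1Cl` gives the lowest of the two numbers in a functional assay on LNCaP cells (Homo sapiens) for antiproliferative activity (a lower number here means a stronger inhibitor, a higher number a weaker inhibitor), at 60 nM. Compound 2 `C=CC[C@@H]1C[C@@H](c2ccc(Cl)c(Cl)c2)[C@H](NC(=O)c2cc(-c3c(Cl)cnn3C)c(Cl)o2)CN1`, which carries vinyl in place of (1H-1,2,4-triazol-1-yl)methyl on a saturated chain carbon bound to a saturated ring carbon, gives 160 nM, a step of a 2.7-fold higher number from compound 1 to compound 2 (0.43 log units; beyond the scatter). Compound 3 `Cn1ncc(Cl)c1-c1cc(C(=O)N[C@@H]2CN[C@H](CC(=O)NCC(O)CO)C[C@H]2c2ccc(Cl)c(Cl)c2)oc1Cl` carries a different replacement: (2,3-dihydroxypropyl)carbamoyl in place of (1H-1,2,4-triazol-1-yl)methyl on a saturated chain carbon bound to a saturated ring carbon. Going by the values given here, only that one step bears on it, and it shows that losing the (1H-1,2,4-triazol-1-yl)methyl group costs a modest amount. For compound 3 a modest weakening is likewise expected, a 2.2-fold higher number from compound 1 to compound 3 (0.34 log units; beyond the scatter), giving an estimated 130 nM within a range of 45 nM to 400 nM.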

Compound 3, half-maximal inhibitory concentration: 660 nM
The estimate for compound 3 lay 5.1-fold (0.71 log units) below the measured number; measured number outside the range, above it.
By their numbers in this assay, from the lowest: compound 1; then compound 2; then compound 3.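

At this position, on a saturated chain carbon bound to a saturated ring carbon, the cost of losing (1H-1,2,4-triazol-1-yl)methyl depends strongly on the replacement. In this assay, (2,3-dihydroxypropyl)carbamoyl gives an 11-fold higher number from compound 1 to compound 3 (1.04 log units; beyond the scatter), a large step, whereas the earlier vinyl step was only modest. This group also falls behind vinyl, with a 4.1-fold higher number from compound 2 to compound 3 (0.62 log units; beyond the scatter), making compound 3 the weakest of the three.

Nothing shown here explains this order. From the compounds shown here alone, whether a primary amine or a carboxylic acid at this position would match compound 1 remains open.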